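Changing the Aromatic Ring on the Amine Nitrogen

The source may report more compounds than this note shows. Statements on the series, on what has been measured and on what is new or still open speak of the compounds shown alone.

Three compounds have been tested in a functional assay on HEK293 cells with D(4) dopamine receptor (Homo sapiens) as the target, read by FLIPR; a higher number here means a larger maximal response, a lower number a smaller maximal response:

Compound 1, `O/N=C(/CCN1CCN(c2ccccn2)CC1)c1ccccc1`, gives 74%.
Compound 2, `Cc1ccc(O)c(/C(CCN2CCN(c3ccccn3)CC2)=N/O)c1`, gives 73%.
Compound 3, `CCO/N=C(\CCN1CCN(c2ccccc2OC)CC1)c1ccccc1`, gives 76%.

The three values lie within the usual scatter of one another, so compound 3 cannot be told apart from compound 1 or compound 2 on these numbers; all three reach a similar largest response.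

Compound 4, `CCO/N=C(\CCN1CCN(c2ncccn2)CC1)c1ccccc1`, has not yet been measured. It differs from compound 3 in one place: pyrimidin-2-yl in place of 2-methoxyphenyl on an amine nitrogen in a ring. Going by the values given here, no measured pair in this set isolates that particular exchange, so there is no directly comparable step to lean on. What the set does show is that compounds carrying different groups on that amine nitrogen, compound 1 and compound 2 included, all land close together.

On that basis the step from compound 3 to compound 4 is expected to stay within the scatter, estimated as a number 4 percentage points lower from compound 3 to compound 4 (within the scatter). Compound 4 is therefore expected to give about 72% in this assay, with a plausible range from 55% to 88%.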

Compound 4, largest response reached (reported as efficacy), in percent of the reference or control that the assay uses: 26%
For compound 4 the middle estimate is 46 percentage points above the measured one, and the stated range ends above it.
By their numbers in this assay, from the lowest: compound 4; then compounds 2, 1 and 3 (each within the scatter of the next).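

In this assay, putting pyrimidin-2-yl in place of 2-methoxyphenyl on the amine nitrogen in the ring gives a number 50 percentage points lower from compound 3 to compound 4 (beyond the scatter), so the group at this position can decide how large a response is reached. The earlier compounds shown here could not show this, since no pair among them changes this group alone, and their close values gave no sign that the position could matter so much. Nothing available here explains the drop.

This single exchange removes the methoxy group and brings in a ring with two hetero atoms at the same time, so it remains open which of these two changes accounts for the loss. A plain phenyl group on that nitrogen would help to separate them, and a 2-ethoxyphenyl group would test how far the response depends on the methoxy group itself.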